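Trimming the chain on a shared core

A few compounds are considered here, and "the series" means these few. Any claim that something is new, unique, unknown or untested is made for them only; others in the source may bear on it.

Compound 1, `Nc1ccccc1NC(=O)c1ccc(COc2ccccc2)cc1`, and compound 2, `CCCc1ccc(OCc2ccc(C(=O)Nc3ccccc3N)cc2)cc1`, share one core and differ only by a propyl in place of hydrogen on an aromatic carbon. In a functional assay on HepG2 cells (Homo sapiens) for antiproliferative activity, read by CCK-8 assay, with a stated time of 72 h (a lower number here means a stronger inhibitor, a higher number a weaker inhibitor), compound 1 gives 6700 nM, and compound 2 gives 4750 nM. Compound 2 thus holds the lowest of the two numbers, but its nearest neighbour, compound 1, sits within the scatter, so no real order between them can be read from these two values alone. Compound 3, `Cc1ccc(OCc2ccc(C(=O)Nc3ccccc3N)cc2)cc1`, differs from compound 2 in one place: hydrogen in place of ethyl on a saturated chain carbon bound to an aromatic carbon. Within the data shown here, the only measured step that bears on this change is a 1.4-fold lower number from compound 1 to compound 2 (0.15 log units; within the scatter), which stayed within the scatter; compound 3 sits between those two endpoints in chain length, so no shift beyond the scatter is expected in this assay. Compound 3 is therefore estimated at 5500 nM, with a range from 2500 nM to 12000 nM. The expected step is a 1.2-fold higher number from compound 2 to compound 3 (0.06 log units; within the scatter).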

Compound 3, half-maximal inhibitory concentration: 6590 nM
Beside the measured number, compound 3's estimate is 1.2-fold (0.08 log units) below it; the range from low to high includes it.
By their numbers in this assay, from the lowest: compounds 2, 3 and 1 (each within the scatter of the next).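

Going from 4-propylphenyl to 4-methylphenyl gives a 1.4-fold higher number from compound 2 to compound 3 (0.14 log units; within the scatter) in this assay, so removing ethyl from the saturated chain carbon bound to an aromatic carbon leaves the number within the scatter. Adding the methyl group alone gives a 1.0-fold lower number from compound 1 to compound 3 (0.01 log units; within the scatter), so the short methyl group also produces no readable change, and hydrogen, methyl and propyl cannot be put in a real order at this place. No evidence is available to explain this flat result.

Going by these compounds, whether a longer chain such as hexyl, or an amine or a carboxylic acid, at this place would move the number beyond the scatter remains open. The compounds shown also leave open how changes elsewhere on the shared core would read.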